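The source may report more compounds than this note shows. Statements on the series, on what has been measured and on what is new or still open speak of the compounds shown alone.

Two compounds built on the same core differ only in the group that sits on a saturated chain carbon bound to an oxygen on an aromatic ring. Compound 1 `CC(C)(N)CCOc1ccc([C@H]2CC[C@]3(CC2)OOC2(O3)C3CC4CC(C3)CC2C4)cc1` carries 2-amino-2-methylpropyl there, and in an ADME assay on the whole organism (strain FVB) for pharmacokinetics, with Mus musculus as the target, read by LC-MS, at a dose of 30 mg/kg by the oral route (a higher number here means more compound in the circulation at the dose given, a lower number less compound in the circulation), compound 1 gives 1050 nM. Compound 2 `c1cc([C@H]2CC[C@]3(CC2)OOC2(O3)C3CC4CC(C3)CC2C4)ccc1OCC1CCNCC1` carries piperidin-4-yl at the same place, and in this assay compound 2 gives 465 nM. Within the data shown here, that single exchange gave a 2.3-fold lower number from compound 1 to compound 2 (0.35 log units; beyond the scatter), so compound 2 stands lowest of the two numbers measured so far.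

Compound 3 `NCCCCOc1ccc([C@H]2CC[C@]3(CC2)OOC2(O3)C3CC4CC(C3)CC2C4)cc1` has not yet been measured. It changes compound 2 in one place: 3-aminopropyl in place of piperidin-4-yl on a saturated chain carbon bound to an oxygen on an aromatic ring. Among the measured compounds shown here, the only measured step that speaks to this change is the one from compound 1 to compound 2, and it was modest in size. The group entering is smaller than the one leaving but brings the same count of donors and acceptors, and nothing measured points to a large move in either direction. The step of a 1.2-fold higher number from compound 2 to compound 3 (0.07 log units; within the scatter) is therefore expected to stay small. Compound 3 is estimated to reach about 550 nM, with a likely range from 220 nM to 1300 nM.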

Compound 3, maximal plasma concentration: 370 nM
For compound 3 the middle estimate is 1.5-fold (0.17 log units) above the measured one; the measured number falls inside the stated range.
By their numbers in this assay, from the lowest: compounds 3 and 2 (each within the scatter of the next); then compound 1.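

In this assay, exchanging piperidin-4-yl for 3-aminopropyl gives a 1.3-fold lower number from compound 2 to compound 3 (0.10 log units; within the scatter), so at this position the ring and the open chain cannot be told apart by these numbers. The exchange of 1-amino-1-methylethyl for 2-aminoethyl on the chain gives a 2.8-fold lower number from compound 1 to compound 3 (0.45 log units; beyond the scatter), which leaves compound 1 standing apart from both other compounds: among these three, the branched chain, and not the presence or absence of a ring, is what accompanies a clearly different number. Nothing available here explains why the numbers fall this way.

The compounds shown leave open whether a single methyl group on the carbon carrying the amine would be enough to keep the number of compound 1, or whether both methyl groups are needed. They also leave open how the number would respond if the primary amine gave way to a tertiary amine or a carboxylic acid, or if the chain leading to the amine were made longer.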